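The source may report more compounds than this note shows. Statements on the series, on what has been measured and on what is new or still open speak of the compounds shown alone.

Among the compounds with values here, in a functional assay on MOLM-13 cells (Homo sapiens) for antiproliferative activity (on this read-out higher numbers stand for weaker inhibition and lower numbers for stronger inhibition), compound 2 (`Cc1c(-c2ccc(-c3ccccc3F)cc2)nc2ccc(F)cc2c1C(=O)NO`) gives 23 nM, the only true number so far. Compound 1 (`Cc1c(-c2ccc(-c3ccccc3F)cc2)nc2ccc(F)cc2c1C(=O)C(F)(F)F`) gives > 3000 nM in this assay, which is a limit of the assay and not a number.

Compound 3 (`CCONC(=O)c1c(C)c(-c2ccc(-c3ccccc3F)cc2)nc2ccc(F)cc12`) differs from compound 2 by one change, ethyl in place of hydrogen on an oxygen, which turns hydroxyamino into ethoxyamino.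

Within the data shown here, only one measured step bears on this change. It is an at least 130-fold lower number from compound 1 to compound 2 (2.11 log units; beyond the scatter), seen with hydroxyamino in place of trifluoromethyl on a carbonyl carbon. Going by these compounds, its true size stays open, as it rests on (the limit of > 3000 nM in this assay, at which 1 of the 2 values shown sits). That step shows that the group on the carbonyl can decide the outcome in this cell assay, and compound 3 alters the same group, although more modestly, since the amide-type nitrogen stays. A large move towards a higher number, meaning weaker inhibition, is therefore expected, probably smaller than the step seen with compound 2. The expected change is a 30-fold higher number from compound 2 to compound 3 (1.48 log units; beyond the scatter). For compound 3 the estimated value is 700 nM, with an expected range from 90 nM to 4000 nM.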

Compound 3, half-maximal inhibitory concentration: 33 nM
Beside the measured number, compound 3's estimate is 21-fold (1.33 log units) above it; the whole stated range lies above it.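

In this assay, a 1.4-fold higher number from compound 2 to compound 3 (0.16 log units; within the scatter), so compound 2 and compound 3 cannot be told apart, and the hydrogen on this oxygen can give way to ethyl without a measurable loss of activity. Within the data shown here, the earlier pair showed only that the group on the carbonyl can decide the outcome; this result shows that the decisive difference does not depend on that oxygen carrying a hydrogen, at least for these two compounds. The ethoxyamino group keeps the large gap to the trifluoromethyl group of compound 1, with an at least 90-fold lower number from compound 1 to compound 3 (1.95 log units; beyond the scatter), but the true size of that gap stays open, as the value of compound 1 is a limit of the assay and not a number: the limit of > 3000 nM in this assay, at which 1 of the 3 values shown sits.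

Ethyl is the only group shown on this oxygen, so it remains open whether a longer chain such as butyl, a benzyl group or a chain ending in an amine would be accepted there as well. Going by these compounds, it also remains open how much the nitrogen itself contributes, a question that a simple amide, a carboxylic acid or a methyl group on that nitrogen could address.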